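The compounds below may be only part of what the source reports. "The series", "measured", "known", "first", "only" and "open" are said of these compounds alone.

The series rests on the core of compound 1 `C=C1C[C@]23C[C@@]1(O)CC[C@H]2c1ccc(O)c(C)c1[C@@H]3Cn1cc(-c2ccccc2)nn1`. In a functional assay on MCF7 cells (Homo sapiens) for cytotoxicity, read by MTT assay, with a stated time of 4 days (a lower number here means a stronger inhibitor, a higher number a weaker inhibitor), compound 1 returns only the limit > 20000 nM, so its position is a limit and not a number. Compound 2 `C=C1C[C@]23C[C@@]1(O)CC[C@H]2c1cc(Br)c(O)c(C)c1[C@@H]3Cn1cc(-c2ccccc2)nn1` carries bromo in place of hydrogen on an aromatic carbon; in this assay compound 2 also returns only the limit > 20000 nM. Compound 3 `C=C1C[C@]23C[C@@]1(O)CC[C@H]2c1ccc(OS(=O)(=O)c2ccc(C)cc2)c(C)c1[C@@H]3Cn1cc(-c2ccccc2)nn1` carries (4-methylphenyl)sulfonyl in place of hydrogen on an oxygen on an aromatic ring; in this assay compound 3 again gives only the limit > 20000 nM. The two steps read a step that the two limits leave unreadable from compound 1 to compound 2 and a step that the two limits leave unreadable from compound 1 to compound 3; all three values sit at the limit of > 20000 nM in this assay, at which 3 of the 3 values shown sit, so neither measured step can be sized.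

Compound 4 `C=C1C[C@]23C[C@@]1(O)CC[C@H]2c1ccc(O)c(C)c1[C@@H]3Cn1cc(-c2ccc(Cl)cc2)nn1` differs from compound 1 by chloro in place of hydrogen on an aromatic carbon. Among the measured compounds shown here, no measured step touches this part of the structure; the two steps that exist, both unreadable, show only that a change on the aromatic ring and a change on its oxygen each left the series at the limit. The expectation for compound 4 in this assay is therefore a value that most probably again comes back as a limit. The expected step is a step that the limit leaves unreadable from compound 1 to compound 4. The estimate for compound 4 is 30000 nM, with a range from 8000 nM to 120000 nM.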

Compound 4, half-maximal inhibitory concentration: > 20000 nM
Compound 4 gave a limit, no number; the forecaster's own chance of this, stated with the estimate: 85%; the middle value does not contradict the limit.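

In this assay compound 4 gives > 20000 nM, a limit and not a number. No new step can be read between compound 1 and compound 4, and the series stays at a single limit: the limit of > 20000 nM in this assay, at which 4 of the 4 values shown sit.

The compounds shown leave open how large any of these steps is and which change to the shared core, if any, would give a readable number.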